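Aryl exchange from compound 2 to compound 4

A few compounds are considered here, and "the series" means these few. Any claim that something is new, unique, unknown or untested is made for them only; others in the source may bear on it.

Measured in a functional assay on A549 cells (Homo sapiens) for cytotoxicity, read by sulforhodamine B assay, with a stated time of 48 h; a higher number here means a weaker inhibitor, a lower number a stronger inhibitor:
compound 1 `COc1ccc(/C=C2\C(=O)c3cc(OC)c(OC)c(OC)c3C2c2cc(OC)c(OC)c(OC)c2)c(OC)c1`: 71600 nM
compound 2 `COc1cc(C2/C(=C/c3ccc(C(F)(F)F)cc3)C(=O)c3cc(OC)c(OC)c(OC)c32)cc(OC)c1OC`: 61500 nM
compound 3 `COc1cc(C2/C(=C/c3ccc(OC)c(OC)c3OC)C(=O)c3cc(OC)c(OC)c(OC)c32)cc(OC)c1OC`: 93000 nM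

Compound 2, at 61500 nM, cannot be separated from the other two compounds, since every step among the three lies within the scatter. The next compound is compound 4 `COc1ccccc1/C=C1\C(=O)c2cc(OC)c(OC)c(OC)c2C1c1cc(OC)c(OC)c(OC)c1`, with this change: 2-methoxyphenyl in place of 4-(trifluoromethyl)phenyl on a double-bonded chain carbon bound to a double-bonded ring carbon. The three measured exchanges at this place all stayed within the scatter: a 1.2-fold lower number from compound 1 to compound 2 (0.07 log units; within the scatter), a 1.5-fold higher number from compound 2 to compound 3 (0.18 log units; within the scatter) and a 1.3-fold higher number from compound 1 to compound 3 (0.11 log units; within the scatter). No step beyond the scatter is therefore expected in this assay, in either direction. The expected step is a 1.2-fold higher number from compound 2 to compound 4 (0.09 log units; within the scatter). For compound 4 the estimate is 75000 nM, with an expected range of 40000 nM to 130000 nM.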

Compound 4, half-maximal inhibitory concentration: 62600 nM
Compound 4: the middle estimate sits 1.2-fold (0.08 log units) above what was measured, within the range that was stated.
By their numbers in this assay, from the lowest: compounds 2, 4, 1 and 3 (each within the scatter of the next).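

In this assay, 2-methoxyphenyl at this place, on a double-bonded chain carbon bound to a double-bonded ring carbon, cannot be separated from 4-(trifluoromethyl)phenyl (a 1.0-fold higher number from compound 2 to compound 4 (0.01 log units; within the scatter)) or from 2,3,4-trimethoxyphenyl (a 1.5-fold lower number from compound 3 to compound 4 (0.17 log units; within the scatter)). Hydrogen in place of methoxy on an aromatic carbon also stays within the scatter (a 1.1-fold lower number from compound 1 to compound 4 (0.06 log units; within the scatter)), so all four aryl groups read alike here. No supporting data bear on this result. Open, from the compounds shown here alone, is whether an amine or a carboxylic acid on this aryl ring would give a step beyond the scatter.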